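A second aromatic ring in place of a bromine

The source may hold more compounds than are shown below. What is called first, only, known or untested is meant among the compounds shown, and "the series" means these compounds.

Three measured compounds share one core, an amide whose nitrogen carries a changing group. Compound 1 `O=C(CCc1cccc2c1B(O)OC2)NCc1ccccc1` carries a benzyl group there; in a functional assay on MDA-MB-231 cells (Homo sapiens) for antiproliferative activity, read by MTT assay, with a stated time of 72 h (on this read-out higher numbers stand for weaker inhibition and lower numbers for stronger inhibition), compound 1 gives > 100000 nM, which is a limit of the assay rather than a number (the limit of > 100000 nM in this assay, at which 1 of the 3 values shown sits). Compound 2 `O=C(CCc1cccc2c1B(O)OC2)Nc1ccc(Br)cc1` carries a 4-bromophenyl group and in this assay gives 5300 nM. Compound 3 `O=C(CCc1cccc2c1B(O)OC2)Nc1cccc(Br)c1` carries a 3-bromophenyl group and in this assay gives 720 nM, the lowest number among the measured compounds. The step of a 7.4-fold lower number from compound 2 to compound 3 (0.87 log units; beyond the scatter) shows that moving the bromine made a clear difference, and an at least 18-fold lower number from compound 1 to compound 2 (1.27 log units; beyond the scatter) together with an at least 130-fold lower number from compound 1 to compound 3 (2.14 log units; beyond the scatter) shows that either bromophenyl gave far lower numbers than benzyl.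

Compound 4 `CSc1ccc(-c2cccc(NC(=O)CCc3cccc4c3B(O)OC4)c2)cc1` changes compound 3 in one place: 4-(methylsulfanyl)phenyl in place of bromo on an aromatic carbon. Going by the values given here, none of the measured steps tests a group of this kind; the nearest evidence is a 7.4-fold lower number from compound 2 to compound 3 (0.87 log units; beyond the scatter), which concerns the same place on the ring but a different, much smaller group. The expectation is therefore a step of modest size at most, or none beyond the scatter, a 1.2-fold lower number from compound 3 to compound 4 (0.08 log units; within the scatter). Compound 4 is thus estimated in this assay at 600 nM, within a range from 120 nM to 3000 nM.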

Compound 4, half-maximal inhibitory concentration: 140 nM
Compound 4: the middle estimate sits 4.3-fold (0.63 log units) above what was measured; low and high end bracket the measured number.
By their numbers in this assay, from the lowest: compound 4; then compound 3; then compound 2. At a limit, above all of these: compound 1.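

The bromine of compound 3 turns out not to mark the largest group this place will accept: in this assay, exchanging that single atom for a much bigger group gives a 5.1-fold lower number from compound 3 to compound 4 (0.71 log units; beyond the scatter), so the number falls further instead of climbing back. A second aromatic ring bearing a methylsulfanyl group is therefore accepted on an aromatic carbon, meta to a large group, and compound 4 now has the lowest number of the four compounds shown. Nothing among the data shown accounts for why this exchange lowers the number.

The compounds shown leave open whether the second ring alone or the methylsulfanyl group on it carries this step, and a plain phenyl, or a phenyl bearing a methoxy group or an amine in place of methylsulfanyl, would tell these two readings apart. Also open, as far as these compounds go, is whether the same second ring would lower the number in the same way if it replaced the bromine of compound 2, where the bromine sits at the other ring position.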